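Series notes: triazole substituent on the shared core

This account rests on a few compounds, and the source may have more. Where it says the series, first, only, none or still open, it means among the compounds named here.

Measured compounds and their numbers:
compound 1 `O=C1O[C@H]([C@@H](O)Cn2cc(-c3ccc(Br)cc3)nn2)C(OCc2ccccc2)=C1OCc1ccccc1` gives 5620 nM
compound 2 `O=C1O[C@H]([C@@H](O)Cn2cc(-c3cc(C(F)(F)F)cc(C(F)(F)F)c3)nn2)C(OCc2ccccc2)=C1OCc1ccccc1` gives 45900 nM
compound 3 `CCCCc1cn(C[C@H](O)[C@H]2OC(=O)C(OCc3ccccc3)=C2OCc2ccccc2)nn1` gives 7910 nM

All three share a core and differ only in the group on the triazole carbon. In a functional assay on MCF7 cells (Homo sapiens) for antiproliferative activity, read by MTT assay, with a stated time of 72 h (on this read-out higher numbers stand for weaker inhibition and lower numbers for stronger inhibition), compound 3 sits second highest of the three numbers; its nearest neighbour is compound 1, and the two lie within the scatter of each other, so no order between them can be read. For the measured compounds named here, compound 2 stands much higher than compound 3 and is the only number beyond the scatter of the rest.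

The next step leads to compound 4 `COc1ccccc1-c1cn(C[C@H](O)[C@H]2OC(=O)C(OCc3ccccc3)=C2OCc2ccccc2)nn1`, with 2-methoxyphenyl in place of butyl on an aromatic carbon. Going by the values given here, the one measured step that bears on it is a 1.4-fold higher number from compound 1 to compound 3 (0.15 log units; within the scatter), which is within the scatter: exchanging an aryl group for butyl left the number essentially unchanged. Among the compounds with values here, compound 2 shows that a differently substituted aryl group can give a far higher number, but no single-change step connects it to compound 3. Going back from butyl to an aryl group is therefore expected to give at most a small step, with a wide range to cover the spread seen across the aryl compounds. Compound 4 is estimated at 6500 nM, range 2500 nM to 18000 nM, which means an expected step of a 1.2-fold lower number from compound 3 to compound 4 (0.09 log units; within the scatter).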

Compound 4, half-maximal inhibitory concentration: > 100000 nM
Compound 4 was reported as a limit (the forecaster's own chance of this, stated with the estimate: 5%); at least 15-fold (1.18 log units) between middle value and limit.
By their numbers in this assay, from the lowest: compounds 1 and 3 (each within the scatter of the next); then compound 2. At a limit, above all of these: compound 4.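

In this assay compound 4 is reported only as a limit, not as a number: the limit of > 100000 nM in this assay, at which 1 of the 4 values shown sits. Even so, this aromatic carbon proves far less forgiving than the earlier compounds suggested: 2-methoxyphenyl gives an at least 12-fold higher number from compound 3 to compound 4 (1.10 log units; beyond the scatter) and an at least 17-fold higher number from compound 1 to compound 4 (1.25 log units; beyond the scatter), both beyond the scatter, whereas butyl in place of 4-bromophenyl had stayed within it. An aryl group here therefore does not by itself keep the number low, as compound 1 and compound 4 both carry one and the step between them is still large.

From the compounds shown here alone, it remains open whether the large step goes with the methoxy group or with the aryl ring that carries it, and a plain phenyl group on this carbon would bear directly on that question. Also open, going by these compounds, is how much the non-aryl side of the series can vary, for instance with a longer chain than butyl or a chain ending in an amine, and whether such groups stay within the scatter of compound 3.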